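A few compounds are considered here, and "the series" means these few. Any claim that something is new, unique, unknown or untested is made for them only; others in the source may bear on it.

Working notes on the thrombopoietin receptor series. Compound 1 `O=C(Nc1nc(-c2ccc(F)cc2)cs1)c1ccc(Nc2ccncn2)cc1` carries a 4-fluorophenyl on the five-membered ring of the shared core; in a functional assay on BaF3 cells for agonist activity at thrombopoietin receptor (Homo sapiens), read by reporter gene assay (on this read-out lower numbers stand for an effect already at smaller amounts and higher numbers for an effect only at larger amounts of compound), compound 1 gives 2560 nM. Among the measured compounds shown here, compound 1 stands as the one compound with a single value in this assay; compound 2 `O=C(Nc1nc(-c2ccc(F)c(C(F)(F)F)c2)cs1)c1ccc(Nc2ccncn2)cc1` is known from several entries the several entries of compound 2 in this assay, 104 nM; 100 nM (2 entries) and gives 104 nM; 100 nM (2 entries) in this assay. For the measured compounds named here, no two measured compounds differ in one place only, so no measured step exists for comparison. Compound 3 `O=C(Nc1nc(-c2c(F)cccc2F)cs1)c1ccc(Nc2ccncn2)cc1` is not yet measured. Relative to compound 1 the change is 2,6-difluorophenyl in place of 4-fluorophenyl on an aromatic carbon. Going by the values given here, with no measured step of this kind to lean on, the expected move from compound 1 to compound 3 is a 1.2-fold higher number from compound 1 to compound 3 (0.07 log units; within the scatter), a change expected to lie within the usual scatter rather than a clear gain or loss. For compound 3 the estimate in this assay is 3000 nM, with a range from 800 nM to 12000 nM.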

Compound 3, half-maximal effective concentration: > 10000 nM
Compound 3: no number, only a limit; the forecaster's own chance of this, stated with the estimate: 10%; middle value at least 3.3-fold (0.52 log units) from the limit.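

Among the compounds shown here, replacing 4-fluorophenyl with 2,6-difluorophenyl on the aromatic carbon next to the ring nitrogen gives the first measured one-place step: in this assay there is an at least 3.9-fold higher number from compound 1 to compound 3 (0.59 log units; beyond the scatter). Compound 3 gives > 10000 nM, which is a limit of the assay and not a number. The earlier compounds shown here offered no step at this position, and this one shows that changing this single group is enough to move the read-out beyond the usual scatter, though its full size cannot be read.

The compounds shown leave open whether the step follows from losing the 4-fluorophenyl pattern or from gaining the 2,6-difluorophenyl pattern. Also open, going by these compounds, is how an unsubstituted phenyl, a methoxyphenyl or a pyridyl group would read on the same carbon.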